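Difluoromethyl on the furan ring: a step without precedent

A few compounds are considered here, and "the series" means these few. Any claim that something is new, unique, unknown or untested is made for them only; others in the source may bear on it.

Measured so far:
compound 1 `Nc1nc(-c2ccco2)nc2sc(CNC3CC3)cc12` gives 1890 nM in an assay on CHO-K1 cells for antagonist activity at adenosine receptor A1 (Homo sapiens), read by a beta-galactosidase reporter, with stated times of 15 min and 6 h; a higher number here means a weaker inhibitor, a lower number a stronger inhibitor
compound 2 `Nc1nc(-c2ccco2)nc2sc(CN3CCC(F)(F)CC3)cc12` gives 2230 nM in this assay
compound 3 `Nc1nc(-c2ccco2)nc2sc(CN3CCC(=O)CC3)cc12` gives 2720 nM in this assay

Compound 2 stands second highest of the three numbers, with compound 1 nearest and compound 3 furthest, and every gap within the scatter. All three measured steps, a 1.2-fold higher number from compound 1 to compound 2 (0.07 log units; within the scatter), a 1.4-fold higher number from compound 1 to compound 3 (0.16 log units; within the scatter) and a 1.2-fold higher number from compound 2 to compound 3 (0.09 log units; within the scatter), exchange the group on the saturated chain carbon bound to an aromatic carbon, and none of them moves the number beyond the scatter.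

Compound 4 `Nc1nc(-c2ccc(C(F)F)o2)nc2sc(CN3CCC(F)(F)CC3)cc12` is the next variant. It differs from compound 2 in one place: difluoromethyl in place of hydrogen on an aromatic carbon. Among the compounds with values here, no measured step touches the furan ring, so none of the three bears directly on this change; the only guidance is that the series has so far been flat across the changes that were made. On that basis the step in this assay from compound 2 to compound 4 is expected to stay within the scatter, without a clear direction, a 1.0-fold lower number from compound 2 to compound 4 (0.01 log units; within the scatter). Compound 4 is therefore estimated at 2200 nM in this assay, with a range from 700 nM to 7000 nM to allow for the lack of any precedent.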

Compound 4, inhibition constant: 17800 nM
The estimate for compound 4 lay 8.1-fold (0.91 log units) below the measured number; measured number above the stated range.
By their numbers in this assay, from the lowest: compounds 1, 2 and 3 (each within the scatter of the next); then compound 4.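

Unlike the three exchanges on the saturated chain carbon, all within the scatter, a change on the furan ring moves the number beyond the scatter in this assay: difluoromethyl in place of hydrogen on the aromatic carbon next to the ring oxygen gives an 8.0-fold higher number from compound 2 to compound 4 (0.90 log units; beyond the scatter) and so a weaker inhibitor. This position is therefore not tolerant in the way the chain carbon has been, although the reading rests on a single pair carrying 4,4-difluoropiperidin-1-yl. No supporting data in hand explain the step.

Still open, from the compounds shown here alone, is whether any group on this carbon gives a similar step or difluoromethyl is particular, which methyl, chlorine or trifluoromethyl there would help separate. Also open, going by these compounds, is whether the step carries over to compounds with cyclopropylamino or 4-oxopiperidin-1-yl on the chain carbon.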